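The compounds below may be only part of what the source reports. "The series", "measured", "known", "first", "only" and "open" are said of these compounds alone.

Measured compounds:
Compound 1 `FC(F)(F)c1nc2c(Br)cccc2c(Cl)c1Br` — in an assay for inhibition of ectonucleoside triphosphate diphosphohydrolase 1 (Homo sapiens), read by malachite green, with a stated time of 10 min (on this read-out higher numbers stand for weaker inhibition and lower numbers for stronger inhibition), compound 1 reaches only the assay limit, > 300000 nM.
Compound 2 `N#Cc1cccc(-c2cccc3c(Cl)c(Br)c(C(F)(F)F)nc23)c1` — in this assay compound 2 likewise reaches only the assay limit, > 300000 nM.

Compound 2 thus stands at the limit of this assay, and so does compound 1. For the measured compounds named here, the one measured step between them, a step that the two limits leave unreadable from compound 1 to compound 2, cannot be read; the evidence is simply (the limit of > 300000 nM in this assay, at which 2 of the 2 values shown sit). Compound 3 `FC(F)(F)c1nc2c(-c3ccsc3)cccc2c(Cl)c1Br` is not yet measured. It differs from compound 2 in one place: thiophen-3-yl in place of 3-cyanophenyl on an aromatic carbon. Going by the values given here, the only measured step concerns a different change and is itself unreadable, so it gives no guide to the size or direction of the step to compound 3. With compound 2 at the limit, compound 3 is expected to give 300000 nM, in the range 100000 nM to 1000000 nM. This estimate means a step of a number no higher from compound 2 to compound 3 (the limit leaves the size open), expected to lie within the scatter.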

Compound 3, half-maximal inhibitory concentration: > 300000 nM
Compound 3: only a limit was reported; the forecaster's own chance of this, stated with the estimate: 85%; the middle value sits exactly at the limit.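

No new step can be read: compound 3, like compound 1 and compound 2, gives only a limit in this assay, and the steps among them cannot be read: the limit of > 300000 nM in this assay, at which 3 of the 3 values shown sit.

The compounds shown leave open which change to the shared core, if any, would give a measurable value in this assay.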